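Chloro for methoxy on a fused bicyclic core

A few compounds are considered here, and "the series" means these few. Any claim that something is new, unique, unknown or untested is made for them only; others in the source may bear on it.

Compound 1, `COc1ccc2[nH]c(C)c(Br)c(=O)c2c1`: 1.62
Compound 2, `Cc1[nH]c2ccc(Cl)cc2c(=O)c1Br`: 2.02
Compound 3, `COc1cccc2c(=O)c(Cc3ccccc3)c(C)[nH]c12`: 2.24

Of the compounds shown here, three have been measured in a physicochemical assay for lipophilicity, at pH 7.4; a lower number here means a more polar compound, a higher number a more lipophilic compound. Compound 1 gives 1.62 and compound 2 gives 2.02; the difference between them is one group on the core. The step is a number 0.40 log units higher from compound 1 to compound 2 (beyond the scatter), and the change is chloro in place of methoxy on an aromatic carbon. Compound 3 gives 2.24 in this assay. Its core differs from that of compound 1, but the difference between the two cores is not broken down here; the two values lie beyond the scatter of each other, while the values of compound 3 and compound 2 lie within it.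

Compound 4, `Cc1[nH]c2c(Cl)cccc2c(=O)c1Cc1ccccc1`, has not yet been measured in this assay. It is made from compound 3 by chloro in place of methoxy on an aromatic carbon. Going by the values given here, this is the same kind of change as the one from compound 1 to compound 2, though the surroundings of the place differ: in the earlier pair the carbon is meta to a fused ring and para to a fused ring, while here it is ortho to a fused ring and meta to a fused ring. Among the compounds with values here, since the only measured example of this change is the step of a number 0.40 log units higher from compound 1 to compound 2 (beyond the scatter), the expectation for compound 4 rests on that single step; a step of similar size, a number 0.40 log units higher from compound 3 to compound 4 (beyond the scatter), is expected. Compound 4 is therefore estimated to give 2.64 in this assay, within a range from 2.25 to 3.05.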

Compound 4, distribution coefficient: 2.78
Compound 4: middle estimate off by 0.14 log units, on the low side; low and high end bracket the measured number.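

In this assay, chloro in place of methoxy on an aromatic carbon gave a number 0.54 log units higher from compound 3 to compound 4 (beyond the scatter), the same direction as a number 0.40 log units higher from compound 1 to compound 2 (beyond the scatter), so the change has now moved the number upward, beyond the scatter, on both of the cores tested. This shows that the earlier step carried over to the core of compound 3, at a place that is ortho to a fused ring and meta to a fused ring, but two pairs do not establish a rule for other cores, and they cannot separate the influence of the place on the ring from that of the rest of the molecule. No measurement shown here accounts for the direction or the size of either step.

The compounds shown leave open whether the same change would give a step in the same direction on a third core or at another place on the aromatic ring. They also leave open how this assay would read with another group at this place, such as fluoro, an amine, a carboxylic acid or a longer chain such as ethoxy.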